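Extending the ester chain by one more carbon

The compounds below may be only part of what the source reports. "The series", "measured", "known", "first", "only" and "open" are said of these compounds alone.

Measured compounds:
compound 1, `CCCCOC(=O)CCC(=O)N1CCN(CCCOc2cc3c(Nc4ccc(F)c(Cl)c4)ncnc3cc2OC)CC1`: 64.1%
compound 2, `CCCCCCOC(=O)CCC(=O)N1CCN(CCCOc2cc3c(Nc4ccc(F)c(Cl)c4)ncnc3cc2OC)CC1`: 63.6%
compound 3, `CCCCCCCCOC(=O)CCC(=O)N1CCN(CCCOc2cc3c(Nc4ccc(F)c(Cl)c4)ncnc3cc2OC)CC1`: 26%

These values come from a functional assay on A549 cells (Homo sapiens) for cytotoxicity, read by MTT assay, with a stated time of 24 h, tested at 60 uM; on this read-out higher numbers stand for a weaker effect at the one concentration tested and lower numbers for a stronger effect. Compound 3 stands lowest of the three numbers, the strongest effect seen: a number 38.1 percentage points lower from compound 1 to compound 3 (beyond the scatter) and a number 37.6 percentage points lower from compound 2 to compound 3 (beyond the scatter), whereas a number 0.5 percentage points lower from compound 1 to compound 2 (within the scatter). Compound 4, `CCCCCCCCCOC(=O)CCC(=O)N1CCN(CCCOc2cc3c(Nc4ccc(F)c(Cl)c4)ncnc3cc2OC)CC1`, differs from compound 3 by methyl in place of hydrogen on a saturated chain carbon, eight bonds along the chain from an oxygen next to a carbonyl group. The measured steps that bear on it are the earlier chain lengthenings: the first was small, the next two large and downward. One further carbon is expected to keep the number near compound 3 or push it a little lower, an estimated a number 6 percentage points lower from compound 3 to compound 4 (within the scatter). Compound 4 is therefore estimated at 20% in this assay, within a range of 5% to 45%.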

Compound 4, a percentage reported as activity, at one concentration (the size of the read-out at that concentration, not a potency): 10.3%
Compound 4: middle estimate off by 9.7 percentage points, on the high side; the measured number falls inside the stated range.
By their numbers in this assay, from the lowest: compound 4; then compound 3; then compounds 2 and 1 (each within the scatter of the next).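

In this assay the fall seen at compound 3 does not stop there: methyl in place of hydrogen, eight bonds along the chain from the oxygen, gives a number 15.7 percentage points lower from compound 3 to compound 4 (beyond the scatter) and so shows that this position still responds to one added carbon. The gaps to the shorter esters are wider, with a number 53.3 percentage points lower from compound 2 to compound 4 (beyond the scatter) and a number 53.8 percentage points lower from compound 1 to compound 4 (beyond the scatter) on the same read-out. No measurement at hand says why the number falls as the chain grows.

On these data alone, whether a longer chain would lower the number further or level off stays open. So does the effect of an amine or a carboxylic acid in place of the added methyl.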